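This account rests on a few compounds, and the source may have more. Where it says the series, first, only, none or still open, it means among the compounds named here.

Of the compounds shown here, two built on a shared core have been measured in a functional assay on L1210 cells (Mus musculus), with a stated time of 12 days; a higher number here means a more potent compound, by a factor of ten per unit of this negative logarithm, a lower number a less potent compound. Compound 1 `COCCC1=C(N2CC2)C(=O)C(C)=C(N2CC2)C1=O` gives 5.57 in this assay, and compound 2 `CCC(COC(N)=O)C1=C(N2CC2)C(=O)C(C)=C(N2CC2)C1=O` gives 6.18, the higher of the two numbers; their gap lies beyond the usual scatter, so compound 2 stands above compound 1 on the numbers shown. Compound 3 `CCC(OC)C1=C(N2CC2)C(=O)C(C)=C(N2CC2)C1=O` has not yet been measured. It differs from compound 2 in one place: methoxy in place of (carbamoyloxy)methyl on a saturated chain carbon bound to a double-bonded ring carbon and a saturated chain carbon. Within the data shown here, no measured pair shows this exact change, so the size of the step must be judged from the two compounds at hand. Compound 3 is expected to move toward compound 1, whose value of 5.57 in this assay belongs to a side chain that also ends in a methoxy. The step from compound 2 to compound 3 is expected to be a number 0.48 log units lower from compound 2 to compound 3 (beyond the scatter), a drop beyond the scatter. For compound 3 in this assay a value of 5.7 is estimated, with a range from 5.2 to 6.2.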

Compound 3, logarithm of the reciprocal of the active concentration, log(1/C): 5.68
Compound 3: the middle estimate sits 0.02 log units above what was measured; measured number inside the range.
By their numbers in this assay, from the lowest: compounds 1 and 3 (each within the scatter of the next); then compound 2.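

In this assay, among these compounds, methoxy in place of (carbamoyloxy)methyl on a saturated chain carbon bound to a double-bonded ring carbon and a saturated chain carbon gives a number 0.50 log units lower from compound 2 to compound 3 (beyond the scatter) and is the first direct reading of this change. 1-Methoxypropyl in place of 2-methoxyethyl on a double-bonded ring carbon gives a number 0.11 log units higher from compound 1 to compound 3 (within the scatter) and so offers no separation between these two methoxy-bearing side chains. The higher number of compound 2 therefore goes with the (carbamoyloxy)methyl group at this saturated chain carbon, at least when set against methoxy there.

As far as these compounds go, how a hydroxymethyl, an aminomethyl or a longer chain ending in carbamoyloxy would stand at this carbon remains open. No measurement at hand gives a reason for either step.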